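The source may hold more compounds than are shown below. What is called first, only, known or untested is meant among the compounds shown, and "the series" means these compounds.

Of the compounds shown here, three that share one core have been tested in an ADME assay on MRC5 cells (Homo sapiens) for cytotoxicity; a higher number here means that more compound is tolerated, a lower number that less compound is tolerated. Compound 1 (`Cc1ccc2nc(-c3ccc(NC(=O)NC[C@H]4O[C@H](n5cc(C)c(=O)[nH]c5=O)C[C@@H]4O)cc3)sc2c1`) gives > 50000 nM, which is a limit of the assay. Compound 2 (`Cc1cn([C@@H]2C[C@H](O)[C@@H](CNC(=O)Nc3ccc(Cc4ccccc4)cc3)O2)c(=O)[nH]c1=O`) gives > 50000 nM, which is also a limit. Compound 3 (`Cc1cn([C@@H]2C[C@H](O)[C@@H](CNC(=O)Nc3ccc(-c4ccc(C(F)(F)F)nc4)cc3)O2)c(=O)[nH]c1=O`) gives > 50000 nM, again a limit and not a number. Compound 3 therefore stands with the other two, at the limit of > 50000 nM in this assay, at which 3 of the 3 values shown sit.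

Compound 4 (`Cc1cn([C@@H]2C[C@H](O)[C@@H](CNC(=O)Nc3ccc(OCc4ccc(Cl)cc4)cc3)O2)c(=O)[nH]c1=O`) replaces the 6-(trifluoromethyl)pyridin-3-yl of compound 3 with (4-chlorobenzyl)oxy: (4-chlorobenzyl)oxy in place of 6-(trifluoromethyl)pyridin-3-yl on an aromatic carbon. Three measured steps exchange groups in the same way on an aromatic carbon: a step that the two limits leave unreadable from compound 1 to compound 2, a step that the two limits leave unreadable from compound 1 to compound 3 and a step that the two limits leave unreadable from compound 2 to compound 3. None of them has a readable size, so they give no measure of how far such an exchange can move this assay.

The expectation rests only on (the limit of > 50000 nM in this assay, at which 3 of the 3 values shown sit). No step beyond the scatter is expected, and no direction can be given, although a shift hidden by the limit remains possible. The estimate means a number no higher from compound 3 to compound 4 (the limit leaves the size open), which is the expected step. Compound 4 is estimated at 50000 nM. The expected range for compound 4 runs from 20000 nM to 80000 nM.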

Compound 4, half-maximal cytotoxic concentration: > 50000 nM
Compound 4: a limit, no number; the forecaster's own chance of this, stated with the estimate: 75%; the middle value sits exactly at the limit.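

In this assay compound 4 gives > 50000 nM, which is a limit and not a number. No step can be read between compound 4 and compound 1, compound 2 or compound 3, and all four stand together: the limit of > 50000 nM in this assay, at which 4 of the 4 values shown sit. The compounds shown leave open whether any of the four differs from the others in this assay, and by how much.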